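The source may hold more compounds than are shown below. What is called first, only, known or untested is meant among the compounds shown, and "the series" means these compounds.

Of the compounds shown here, three sharing one core have been tested so far in a functional assay on SK-MEL-28 cells (Homo sapiens) for inhibition; on this read-out higher numbers stand for weaker inhibition and lower numbers for stronger inhibition. In this assay, compound 1 `CC(=O)Oc1ccc(/C=C/c2ccc3ccccc3c2)cc1` gives > 5000 nM, which is a limit and not a number. Compound 2 `FC(F)(F)Oc1ccc(/C=C/c2ccc3ccccc3c2)cc1` gives > 5000 nM, again a limit. Compound 3 `FC(F)(F)c1ccc(/C=C/c2ccc3ccccc3c2)cc1` gives > 5000 nM, also a limit. Compound 3 therefore has no exact position, and the whole set rests on (the limit of > 5000 nM in this assay, at which 3 of the 3 values shown sit).

The next compound is compound 4 `CN(C)c1ccc(/C=C/c2ccc3ccccc3c2)cc1`, which has dimethylamino in place of trifluoromethyl on an aromatic carbon, para to a large group: dimethylamino in place of trifluoromethyl on an aromatic carbon. The measured steps that bear on this change are a step that the two limits leave unreadable from compound 1 to compound 2, a step that the two limits leave unreadable from compound 1 to compound 3 and a step that the two limits leave unreadable from compound 2 to compound 3, and each one exchanges the group at this same place. Both ends of each step are limits, so none has a readable size, and none shows a direction.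

Three different groups at this place have thus produced no number in this assay. On that evidence, no clear gain in inhibition is expected, and another limit is the likeliest result. The expected step is a step that the limit leaves unreadable from compound 3 to compound 4, a rough estimate given how little the limits reveal. For compound 4, the estimated value is 7000 nM, with an expected range from 2000 nM to 20000 nM.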

Compound 4, half-maximal inhibitory concentration: 3660 nM
Compound 4: middle estimate off by 1.9-fold (0.28 log units), on the high side; the range from low to high includes it.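

In this assay, among these compounds, dimethylamino is the first of the four groups at this place, on an aromatic carbon para to a large group, to give a measured number and not a limit. Putting it in place of trifluoromethyl gives an at least 1.3-fold lower number from compound 3 to compound 4 (0.13 log units; that floor lies within the scatter), putting it in place of trifluoromethoxy gives an at least 1.3-fold lower number from compound 2 to compound 4 (0.13 log units; that floor lies within the scatter), and putting it in place of acetoxy gives an at least 1.3-fold lower number from compound 1 to compound 4 (0.13 log units; that floor lies within the scatter). From the compounds shown here alone, each of these steps is only a floor, so the true size of the change remains unknown and could be small or large, and the series still leans heavily on a single limit: the limit of > 5000 nM in this assay, at which 3 of the 4 values shown sit.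

Among the compounds shown here, it remains open whether a plain amine, a methylamino group or a diethylamino group at this place would also give a number, and how that number would compare with the one for compound 4. Also open, going by these compounds, is whether changes elsewhere in the shared core would shift the read-out more than the exchange of this one group has done.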